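Dimethoxyphenyl in Place of Benzodioxinyl: Cytotoxicity Outlook

The source may hold more compounds than are shown below. What is called first, only, known or untested is meant among the compounds shown, and "the series" means these compounds.

In an ADME assay on HEK293 cells (Homo sapiens) for cytotoxicity, read by MTT assay, with a stated time of 36 h (on this read-out lower numbers stand for stronger inhibition and higher numbers for weaker inhibition), compound 1 `O=C(c1ccc2c(c1)OCCO2)C1CCN(Cc2coc(-c3ccc(F)cc3)n2)CC1` gives > 150 ug/mL, which is a limit of the assay and not a number.
In this assay compound 2 `O=C(c1ccc2c(c1)OCCO2)C1CCN(Cc2coc(-c3ccccc3)n2)CC1` gives > 150 ug/mL, again a limit.
In this assay compound 3 `O=C(c1ccc2c(c1)OCCO2)C1CCN(Cc2coc(-c3ccoc3)n2)CC1` gives > 150 ug/mL, also a limit.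

Compound 1 therefore stands at the limit of > 150 ug/mL in this assay, at which 3 of the 3 values shown sit, so no order among the three can be read. The steps a step that the two limits leave unreadable from compound 1 to compound 2 and a step that the two limits leave unreadable from compound 1 to compound 3 alter only the group on the oxazole and are unreadable. Within the data shown here, compound 4 `COc1ccc(C(=O)C2CCN(Cc3coc(-c4ccc(F)cc4)n3)CC2)cc1OC` differs from compound 1 by 3,4-dimethoxyphenyl in place of 2,3-dihydro-1,4-benzodioxin-6-yl on a carbonyl carbon, a place no measured step touches. With the limits offering nothing beyond the scatter, the step that the limit leaves unreadable from compound 1 to compound 4 is expected to be none beyond it. Compound 4 is thus estimated at 200 ug/mL, within 100 ug/mL to 400 ug/mL, most likely reported again as a limit.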

Compound 4, half-maximal inhibitory concentration: > 150 ug/mL
Compound 4 was reported as a limit; the forecaster's own chance of this, stated with the estimate: 85%; the middle value is on the limit's open side.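

In this assay, among these compounds, compound 4 gives > 150 ug/mL, again a limit, so no step from compound 1 to compound 4 can be read. The compounds shown leave open where the actual values of compounds 1 to 4 lie, and whether any of these exchanges changes them.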